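Adding a carboxy group to a second core

The compounds below may be only part of what the source reports. "The series", "measured", "known", "first", "only" and "open" are said of these compounds alone.

Compound 1 `CC1CCC(N=Nc2ccccc2)=C2N(C)C=C(C(=O)O)C(=O)N21` gives the limit > 100 umol/kg in a functional assay on the whole organism with Rattus norvegicus as the target; a lower number here means that less compound is needed, a higher number that more compound is needed for the effect.
Compound 2 `CC1CCC(N=Nc2ccccc2C(=O)O)=C2N(C)C=C(C(=O)O)C(=O)N21` gives the limit > 100 umol/kg.
Compound 3 `CC1CCC(C)(N=Nc2ccccc2)c2ncc(C(=O)O)c(=O)n21` gives the limit > 100 umol/kg.

Every value here is a limit of the assay, not a number, as the limit of > 100 umol/kg in this assay, at which 3 of the 3 values shown sit, shows. The step that the two limits leave unreadable from compound 1 to compound 2 therefore cannot be read; the change behind it is carboxy in place of hydrogen on an aromatic carbon. Compound 4 `CC1CCC(C)(N=Nc2ccccc2C(=O)O)c2ncc(C(=O)O)c(=O)n21` is still unmeasured and differs from compound 3 by the same change, (carboxy in place of hydrogen on an aromatic carbon). The difference between the two cores of compound 1 and compound 3 is not broken down here. Because the limit of > 100 umol/kg in this assay, at which 3 of the 3 values shown sit, places compound 3 at the limit, and the step that the two limits leave unreadable from compound 1 to compound 2 stayed unreadable on the other core, the expected step that the limit leaves unreadable from compound 3 to compound 4 is small. Compound 4 is expected to give about 150 umol/kg, between 40 umol/kg and 600 umol/kg, most likely again a limit.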

Compound 4, dose for 50% inhibition: > 100 umol/kg
Compound 4 gave a limit, no number; the forecaster's own chance of this, stated with the estimate: 75%; the middle value is on the limit's open side.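

Among the compounds shown here, compound 3 and compound 4 both give only a limit, so no step from one to the other can be read: the limit of > 100 umol/kg in this assay, at which 4 of the 4 values shown sit.

The compounds shown leave open how much of any of them is needed in this assay and whether carboxy in place of hydrogen changes that dose on either core.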